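A few compounds are considered here, and "the series" means these few. Any claim that something is new, unique, unknown or untested is made for them only; others in the source may bear on it.

Measured so far in a physicochemical assay, read by spectrophotometry, with a stated time of 30 min; on this read-out higher numbers stand for weaker inhibition and lower numbers for stronger inhibition:

- Compound 1 `O=C(CCc1nc2ccccc2c(=O)[nH]1)N/N=C/c1ccc(O)c(O)c1`: 113000000 nM
- Compound 2 `O=C(CCc1nc2ccccc2c(=O)[nH]1)N/N=C/c1cc(O)c(O)c(O)c1`: 81000000 nM
- Compound 3 `O=C(CCCc1nc2ccccc2c(=O)[nH]1)N/N=C/c1ccc(O)cc1`: 214000000 nM

Compound 1 and compound 2 share one core; compound 3 carries a different one, and the difference between the two cores is not broken down here. Within the first pair the change is hydroxy in place of hydrogen on an aromatic carbon, and it moved the read-out by a 1.4-fold lower number from compound 1 to compound 2 (0.14 log units; within the scatter).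

Compound 4 `O=C(CCCc1nc2ccccc2c(=O)[nH]1)N/N=C/c1ccc(O)c(O)c1` is not yet measured. It is made from compound 3 by hydroxy in place of hydrogen on an aromatic carbon, the same kind of change as that from compound 1 to compound 2, though the surroundings are not identical: in compound 2 the entering hydroxy is also meta to a hydroxy group, whereas in compound 4 it is only ortho to a hydroxy group and meta to a large group.

For compound 4 the expected step in this assay is a 1.5-fold lower number from compound 3 to compound 4 (0.18 log units; within the scatter), resting on the earlier step of a 1.4-fold lower number from compound 1 to compound 2 (0.14 log units; within the scatter) from compound 1 and on compound 3 giving 214000000 nM. Compound 4 is thus estimated at 140000000 nM, with a range from 70000000 nM to 300000000 nM.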

Compound 4, half-maximal inhibitory concentration: 95000000 nM
Beside the measured number, compound 4's estimate is 1.5-fold (0.17 log units) above it; low and high end bracket the measured number.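

In this assay, hydroxy in place of hydrogen on an aromatic carbon gives a 2.3-fold lower number from compound 3 to compound 4 (0.35 log units; beyond the scatter) and, on the other core, the same kind of change gives a 1.4-fold lower number from compound 1 to compound 2 (0.14 log units; within the scatter) so the number falls on both cores, though only the new step lies beyond the scatter. With a single pair on each core and different surroundings, 4-hydroxyphenyl to 3,4-dihydroxyphenyl being a change from one hydroxy group to two while the other pair starts with two, this shows a shared direction but no fixed size for the change on either core. Nothing measured here bears on why the two steps differ in size.

From the compounds shown here alone, whether a methoxy group or an amine entering at the same place would move the number in the same direction on both cores stays open. Also open, going by these compounds, is how the change behaves on a core with a longer chain.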